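Changing the ether chain of compound 1

The source may hold more compounds than are shown below. What is called first, only, known or untested is meant among the compounds shown, and "the series" means these compounds.

Compound 1 `CC(C)(O)COc1ccc2c(Oc3ccc(Nc4nccc5[nH]cc(-c6ccc(F)cc6)c(=O)c45)cc3F)ccnc2c1` gives 3400 nM
Compound 2 `COCCOc1cc2nccc(Oc3ccc(Nc4nccc5[nH]cc(-c6ccc(F)cc6)c(=O)c45)cc3F)c2cc1OC` gives 4600 nM

For the measured compounds named here, both values come from a functional assay on HT-29 cells (Homo sapiens) for antiproliferative activity, read by MTT assay, with a stated time of 72 h (on this read-out higher numbers stand for weaker inhibition and lower numbers for stronger inhibition), and lie within the scatter of each other, so compound 1 cannot be told apart from compound 2, the only other measured compound. Compound 3 `COCCOc1ccc2c(Oc3ccc(Nc4nccc5[nH]cc(-c6ccc(F)cc6)c(=O)c45)cc3F)ccnc2c1` has not yet been measured. Going by the values given here, it differs from compound 1 by carrying methoxymethyl in place of 1-hydroxy-1-methylethyl on a saturated chain carbon bound to an oxygen on an aromatic ring and no measured pair shows this change alone. With compound 2 at 4600 nM so close to compound 1, no step beyond the scatter is expected in this assay and no direction is favoured. The expected change is small, namely a 1.2-fold higher number from compound 1 to compound 3 (0.07 log units; within the scatter) in all. For compound 3 the estimate is 4000 nM with an expected range from 1800 nM to 9000 nM in this measurement.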

Compound 3, half-maximal inhibitory concentration: 6500 nM
Beside the measured number, compound 3's estimate is 1.6-fold (0.21 log units) below it; the range from low to high includes it.
By their numbers in this assay, from the lowest: compounds 1, 2 and 3 (each within the scatter of the next).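

In this assay, replacing 1-hydroxy-1-methylethyl with methoxymethyl on a saturated chain carbon bound to an oxygen on an aromatic ring gives a 1.9-fold higher number from compound 1 to compound 3 (0.28 log units; within the scatter), so taking the hydrogen-bond donor out of this chain does not move the number beyond the scatter. Hydrogen in place of methoxy on an aromatic carbon gives a 1.4-fold higher number from compound 2 to compound 3 (0.15 log units; within the scatter), so this second single change on the shared core cannot be told from the scatter either. Nothing available explains these small steps or links them to any property of the groups.

On these data alone, whether an amine such as morpholine, a carboxylic acid or a longer chain in this place would move the number beyond the scatter remains open. As far as these compounds go, it also remains open whether either change would read the same way in a different cell line.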